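Fluorine Added to a Core Already at the Assay Limit

A few compounds are considered here, and "the series" means these few. Any claim that something is new, unique, unknown or untested is made for them only; others in the source may bear on it.

Compound 1 `N#Cc1ccc2ccc(Oc3ccccc3OCCn3ccc(=O)[nH]c3=O)cc2c1` and compound 3 `N#Cc1ccc2ccc(Oc3ccc(F)cc3OCCn3ccc(=O)[nH]c3=O)cc2c1` differ by fluoro in place of hydrogen on an aromatic carbon. In a toxicity assay on MT2 cells (Homo sapiens) for cytotoxicity, read by MTT assay (a lower number here means that less compound is tolerated, a higher number that more compound is tolerated), compound 1 gives 15000 nM. For compound 3 the result in this assay is only a limit, > 100000 nM. That makes an at least 6.6-fold higher number from compound 1 to compound 3 (0.82 log units; beyond the scatter). Compound 2 `N#Cc1ccc2c(F)cc(Oc3ccccc3OCCn3ccc(=O)[nH]c3=O)c(Cl)c2c1` has a different core; the difference between the two cores is not broken down here. In this assay compound 2 also reaches only a limit, > 100000 nM. Compound 4 `N#Cc1ccc2c(F)cc(Oc3ccc(F)cc3OCCn3ccc(=O)[nH]c3=O)c(Cl)c2c1` differs from compound 2 by fluoro in place of hydrogen on an aromatic carbon, the same change as between compound 1 and compound 3. The expected step is a step that the limit leaves unreadable from compound 2 to compound 4, which rests on the limit of > 100000 nM in this assay, at which 2 of the 3 values shown sit, and on an at least 6.6-fold higher number from compound 1 to compound 3 (0.82 log units; beyond the scatter). Compound 4 is therefore estimated in this assay at 150000 nM, between 80000 nM and 400000 nM, most likely reported only as a limit.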

Compound 4, half-maximal cytotoxic concentration: 28000 nM
Compound 4: the middle estimate sits 5.4-fold (0.73 log units) above what was measured; the whole stated range lies above it.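

On the core of compound 2, fluoro in place of hydrogen on an aromatic carbon gives an at least 3.5-fold lower number from compound 2 to compound 4 (0.55 log units; beyond the scatter) in this assay. Set beside the step on the core of compound 1, this shows that the change does not carry from one core to the other, as the two steps run in opposite directions: the same change on two cores in this assay, an at least 6.6-fold higher number (0.82 log units; beyond the scatter) from compound 1 to compound 3 and an at least 3.5-fold lower number (0.55 log units; beyond the scatter) from compound 2 to compound 4, at least 23-fold (1.37 log units) apart, beyond the scatter of two such steps

Each step has one end at a limit, so its full size stays unknown, and the two cores do not show why the outcome differs or how any other core would respond: the limit of > 100000 nM in this assay, at which 2 of the 4 values shown sit.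

Going by these compounds, it remains open whether a methoxy group or an amine in place of that hydrogen would also give opposite steps on the two cores. On these data alone, it also remains open which of the differences between the two cores reverses the step.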